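Swapping Bromo for Methylsulfanyl on a Purine Nucleoside

The source may report more compounds than this note shows. Statements on the series, on what has been measured and on what is new or still open speak of the compounds shown alone.

Of the compounds shown here, two have been measured in a functional assay on PHA-Ly cells (Homo sapiens) (on this read-out higher numbers stand for weaker inhibition and lower numbers for stronger inhibition), so far. Compound 1 `CNc1nc(SC)nc2c1ncn2[C@@H]1C[C@@H](O)[C@H](CO)O1` gives 81 uM in this assay. Compound 2 `Nc1nc(Br)nc2c1ncn2[C@@H]1C[C@@H](O)[C@H](CO)O1` gives 1.6 uM in this assay, the lowest of the two numbers; its nearest neighbour is compound 1, whose number is higher by a margin beyond the scatter. Among the measured compounds shown here, no step between two measured compounds that differ in one place is available, so the effect of a single change has not been seen directly.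

Compound 3 `CSc1nc(N)c2ncn([C@@H]3C[C@@H](O)[C@H](CO)O3)c2n1` is the next compound to be measured in this assay. It differs from compound 2 in one place: methylsulfanyl in place of bromo on an aromatic carbon. For the measured compounds named here, with no matching step on record, the direction is uncertain; the author expects a step from compound 2 to compound 3 of a 6.3-fold higher number from compound 2 to compound 3 (0.80 log units; beyond the scatter) toward a higher number, beyond the scatter. Compound 3 is therefore estimated at 10 uM in this assay, within a range from 2.5 uM to 50 uM.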

Compound 3, concentration for 50% inhibition: 82 uM
Beside the measured number, compound 3's estimate is 8.2-fold (0.91 log units) below it, outside the stated range (above it).
By their numbers in this assay, from the lowest: compound 2; then compounds 1 and 3 (each within the scatter of the next).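

In this assay, methylsulfanyl in place of bromo on the aromatic carbon between two ring nitrogen atoms gives a 51-fold higher number from compound 2 to compound 3 (1.71 log units; beyond the scatter) and is a large step, the first direct sign that this position responds to a single change. On this read-out, the lower number belongs to the bromo compound. Hydrogen in place of methyl on the nitrogen on the aromatic ring gives a 1.0-fold higher number from compound 1 to compound 3 (0.01 log units; within the scatter) and stays within the scatter, so with methylsulfanyl on the aromatic carbon, this change does not separate the two compounds. Nothing shown here accounts for the large step at the aromatic carbon. On these data alone, whether chloro, methoxy or a plain hydrogen at that carbon would give a number nearer that of compound 2 remains open. So does whether methyl on the nitrogen would matter with bromo on the aromatic carbon.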